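This account rests on a few compounds, and the source may have more. Where it says the series, first, only, none or still open, it means among the compounds named here.

Measured compounds in an assay for inhibition of ATP-dependent RNA helicase DDX3X (Homo sapiens), read by FRET, with a stated time of 40 min, in the presence of a further agent that is not named here; on this read-out higher numbers stand for weaker inhibition and lower numbers for stronger inhibition:
- compound 1 `CCCCc1cn(-c2cccc(S(=O)(=O)Nc3ccccc3C(F)(F)F)c2)nn1`, giving 400 nM
- compound 2 `CCOCc1cn(-c2cccc(S(=O)(=O)Nc3ccccc3C(F)(F)F)c2)nn1`, giving 400 nM
- compound 3 `CCCCc1cn(-c2cccc(S(=O)(=O)Nc3ccccc3O)c2)nn1`, giving 400 nM

On these numbers compound 3 stands level with the other two: its nearest neighbour is compound 1, its furthest compound 2, and neither gap reaches beyond the scatter. The two measured steps are both flat. From compound 1 to compound 2 the change is ethoxy in place of propyl on a saturated chain carbon bound to an aromatic carbon, with no change at the digits printed from compound 1 to compound 2 (within the scatter). From compound 1 to compound 3 the change is hydroxy in place of trifluoromethyl on an aromatic carbon, with no change at the digits printed from compound 1 to compound 3 (within the scatter).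

Compound 4 `CCCCc1cn(-c2cccc(S(=O)(=O)Nc3ccccc3OC)c2)nn1` is not yet measured. Against compound 3 the difference is methyl in place of hydrogen on an oxygen on an aromatic ring. Going by the values given here, the step that bears on it most closely is the one from compound 1 to compound 3, which altered the same aromatic carbon's substituent without any movement in this assay; there is no measured step that touches the oxygen itself. Given that flat step, the expected step from compound 3 to compound 4 is no change at the digits printed from compound 3 to compound 4 (within the scatter), that is, none beyond the scatter. Compound 4 is therefore estimated at 400 nM in this assay, within a range from 150 nM to 1000 nM.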

Compound 4, half-maximal inhibitory concentration: 180 nM
The estimate for compound 4 lay 2.2-fold (0.35 log units) above the measured number; the range from low to high includes it.
By their numbers in this assay, from the lowest: compound 4; then compounds 1, 2 and 3 (each within the scatter of the next).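

In this assay, going by these compounds alone, the aromatic carbon carrying trifluoromethyl or hydroxy had looked indifferent to its substituent, as those two groups read level, but methoxy is the first group there to move the number, with a 2.2-fold lower number from compound 1 to compound 4 (0.35 log units; beyond the scatter) as a modest step. The oxygen on that ring is also a place that responds: methyl in place of hydrogen gives a 2.2-fold lower number from compound 3 to compound 4 (0.35 log units; beyond the scatter) and so shows that, in this small set, the hydrogen on that oxygen is not needed for inhibition at the level of the hydroxy compound. Nothing shown here explains why methoxy differs from the other two groups, so the result stands only as a modest shift in the number.

Going by these compounds, it stays open whether the response at this carbon continues with a larger ether such as propoxy, or changes direction with an amine or a carboxylic acid in the same place. On these data alone, it is equally open whether methoxy gives a step of the same size on the ethoxy-bearing chain of compound 2, where the propyl part of the butyl chain has already been exchanged without any shift.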